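Chloro in place of hydroxy on an aromatic carbon

The compounds below may be only part of what the source reports. "The series", "measured", "known", "first", "only" and "open" are said of these compounds alone.

In a functional assay on HT-29 cells (Homo sapiens) for antiproliferative activity, with a stated time of 48 h (a higher number here means that more compound is needed for the effect, a lower number that less compound is needed), compound 2 (`O=C(CCCCCCC(=O)Nc1ccc(O)cc1)NO`) gives 15000 nM as its value, close to compound 1 (`Nc1ccc(NC(=O)CCCCCCC(=O)NO)cc1`) at 18000 nM and higher than compound 3 (`O=C(CCCCCCC(=O)Nc1cccc(C(F)(F)F)c1)NO`) at 6400 nM in this small set. Compound 4 (`O=C(CCCCCCC(=O)Nc1ccc(Cl)cc1)NO`) is compound 2 with one change (chloro in place of hydroxy on an aromatic carbon), in words chloro in place of hydroxy on an aromatic carbon. Among the measured compounds shown here, the only measured step at that carbon, a 1.2-fold lower number from compound 1 to compound 2 (0.08 log units; within the scatter) for hydroxy in place of amino, stayed within the scatter. Compound 3, which carries trifluoromethyl and no hydroxy, holds the lowest value at 6400 nM and hints at a modest drop. A small step toward a lower number is therefore expected, namely a 1.7-fold lower number from compound 2 to compound 4 (0.22 log units; within the scatter) in this assay as estimated here. Compound 4 is estimated at 9000 nM (expected range 4000 nM to 18000 nM).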

Compound 4, half-maximal effective concentration: 2100 nM
Beside the measured number, compound 4's estimate is 4.3-fold (0.63 log units) above it, and the stated range ends above it.
By their numbers in this assay, from the lowest: compound 4; then compound 3; then compounds 2 and 1 (each within the scatter of the next).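

In this assay, this carbon, para to a large group, now proves sensitive to what it carries: chloro in place of hydroxy gives a 7.1-fold lower number from compound 2 to compound 4 (0.85 log units; beyond the scatter) and chloro in place of amino gives an 8.6-fold lower number from compound 1 to compound 4 (0.93 log units; beyond the scatter) in the same series. Among the compounds shown here, the step between amino and hydroxy stayed within the scatter, so these are the first steps at this carbon to go beyond it. No available evidence explains what sets chloro apart from those two groups.

On these data alone, whether fluoro, bromo or methyl at this carbon would match chloro remains open. Also open, as far as these compounds go, is how chloro would fare on a different carbon of the ring.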